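Replacing (oxetan-3-yl)methyl with piperidin-4-yl on an aromatic nitrogen

This account rests on a few compounds, and the source may have more. Where it says the series, first, only, none or still open, it means among the compounds named here.

compound 1 `CCCCn1nc(C(=O)N[C@H]2COc3ccccc3N(C)C2=S)nc1Cc1ccccc1` gives 510 nM
compound 2 `CC(C)Cn1nc(C(=O)N[C@H]2COc3ccccc3N(C)C2=S)nc1Cc1ccccc1` gives 1230 nM
compound 3 `CN1C(=S)[C@@H](NC(=O)c2nc(Cc3ccccc3)n(CC3COC3)n2)COc2ccccc21` gives 2830 nM

In a functional assay on HT-29 cells (Homo sapiens) for inhibition, read by luminescence and CellTiter-Glo, with a stated time of 24 h (a higher number here means that more compound is needed for the effect, a lower number that less compound is needed), compound 3 holds the highest of the three numbers, beyond the scatter of both others. Compound 4 `CN1C(=S)[C@@H](NC(=O)c2nc(Cc3ccccc3)n(C3CCNCC3)n2)COc2ccccc21` carries piperidin-4-yl in place of (oxetan-3-yl)methyl on an aromatic nitrogen. The nearest evidence is modest: a 2.4-fold higher number from compound 1 to compound 2 (0.38 log units; beyond the scatter), a 2.3-fold higher number from compound 2 to compound 3 (0.36 log units; beyond the scatter) and a 5.5-fold higher number from compound 1 to compound 3 (0.74 log units; beyond the scatter). All three changes concern this same group, yet none brings in piperidin-4-yl, so the guidance is weak. A modest rise in this assay is expected, with wide uncertainty: the expected step is a 2.1-fold higher number from compound 3 to compound 4 (0.33 log units; beyond the scatter). The estimate for compound 4 is 6000 nM, with an expected range of 1800 nM to 20000 nM.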

Compound 4, half-maximal effective concentration: 1000 nM
Compound 4: middle estimate off by 6.0-fold (0.78 log units), on the high side, outside the stated range (below it).
By their numbers in this assay, from the lowest: compounds 1, 4 and 2 (each within the scatter of the next, the first and the last beyond it); then compound 3.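

The position accepts a six-membered ring with a hydrogen-bond donor, attached directly to the aromatic nitrogen: in this assay, piperidin-4-yl gives a 2.8-fold lower number from compound 3 to compound 4 (0.45 log units; beyond the scatter) and so recovers what the (oxetan-3-yl)methyl group had lost. It also stands level with the open chains, with a 1.2-fold lower number from compound 2 to compound 4 (0.09 log units; within the scatter) and a 2.0-fold higher number from compound 1 to compound 4 (0.29 log units; within the scatter) both printed as within the scatter. Nothing measured here explains this result.

On these data alone, what the ring nitrogen contributes remains open. Tetrahydropyran-4-yl, with oxygen in its place, would test this directly, and 1-methylpiperidin-4-yl would show whether that nitrogen can carry a substituent.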